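A few compounds are considered here, and "the series" means these few. Any claim that something is new, unique, unknown or untested is made for them only; others in the source may bear on it.

Measured compounds:
- Compound 1, `Nc1ccccc1-c1ncc(C(=O)O)c(=O)[nH]1`, in a functional assay on the whole organism (strain Sprague-Dawley) for inhibition, with Rattus norvegicus as the target, with a stated time of 10 min (a lower number here means that less compound is needed, a higher number that more compound is needed for the effect), compound 1 gives 50 mg/kg.
- Compound 2, `CCOc1ccc(S(N)(=O)=O)cc1-c1ncc(C(=O)O)c(=O)[nH]1`. For compound 2 this assay reports only a limit, > 50 mg/kg.
- Compound 3, `CCOC(=O)c1cnc(-c2ccccc2N)[nH]c1=O`; in this assay compound 3 has "not determined" (no result reported), no result reported.

Compound 3 therefore stands nowhere on the numbers shown: of the three entries, one is a number, one is a limit, and the entry for compound 3 is empty. For the measured compounds named here, the only fixed point in the set is the limit (the limit of > 50 mg/kg in this assay, at which 1 of the 3 values shown sits), and no pair of measured compounds differs in a single place, so no measured step exists to calibrate against.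

Compound 4, `CCOC(=O)c1cnc(-c2ccccc2OCC2CC2)[nH]c1=O`, is the next compound to be measured in this assay. It differs from compound 3 by cyclopropylmethoxy in place of amino on an aromatic carbon. With no step from compound 3 to anything else, and no number for compound 3 itself, the size of the step into compound 4 cannot be read from the series; the expectation is that compound 4 lands in the same region as the two values already shown, with no direction that can be defended beyond the scatter.

The estimate for compound 4 in this assay is 45 mg/kg, within a range from 12 mg/kg to 100 mg/kg.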

Compound 4, dose for 50% inhibition: 0.3 mg/kg
Beside the measured number, compound 4's estimate is 150-fold (2.18 log units) above it; measured number below the stated range.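

For the compounds shown here, compound 3 carries no number in this assay, so no step to compound 4 can be read from this result. The compounds shown leave open whether cyclopropylmethoxy in place of amino accounts for compound 4 giving 0.3 mg/kg in this series. Nothing shown bears on the cause of that result.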